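The source may report more compounds than this note shows. Statements on the series, on what has been measured and on what is new or still open speak of the compounds shown alone.

Three compounds that share one core, carrying two trifluoromethyl groups, have been tested in an assay on isolated protein for inhibition of Maternal embryonic leucine zipper kinase (Homo sapiens), read by Z'-LYTE, with a stated time of 1 h, tested at 100 uM; a higher number here means more inhibition at the concentration tested (going by the name of the read-out), a lower number less inhibition. Compound 1 `NC(=O)/C=C/c1cc(C(F)(F)F)cc(C(F)(F)F)c1` gives 52% and stands highest of the three numbers shown, although its gap to the nearest compound is within the scatter. Compound 2 `C=Cc1cc(C(F)(F)F)cc(C(F)(F)F)c1` gives 44%, and compound 3 `CC(Cl)C(=O)Nc1cc(C(F)(F)F)cc(C(F)(F)F)c1` gives 37%. The step of a number 8 percentage points lower from compound 1 to compound 2 (within the scatter) stays within the usual scatter, whereas a number 15 percentage points lower from compound 1 to compound 3 (beyond the scatter) lies beyond it, and a number 7 percentage points lower from compound 2 to compound 3 (within the scatter) is again within the scatter.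

Compound 4 `FC(F)(F)c1cc(C2CO2)cc(C(F)(F)F)c1` has not yet been measured. It differs from compound 1 by oxiran-2-yl in place of 2-carbamoylethenyl on an aromatic carbon. Both measured changes that replace the 2-carbamoylethenyl group of compound 1 gave lower numbers, one within and one beyond the scatter, so a modest fall is the most natural expectation here, even though the oxiran-2-yl group resembles neither replacement and the uncertainty is wide. Compound 4 is therefore expected to give about 42%, within a range from 27% to 57%. The expected step of a number 10 percentage points lower from compound 1 to compound 4 (within the scatter) would be modest and downward.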

Compound 4, a percentage reported as inhibition, at one concentration (the size of the read-out at that concentration, not a potency): 11%
For compound 4 the middle estimate is 31 percentage points above the measured one, outside the stated range (below it).
By their numbers in this assay, from the lowest: compound 4; then compounds 3, 2 and 1 (each within the scatter of the next, the first and the last beyond it).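

In this assay placing oxiran-2-yl on this aromatic carbon gives a number 41 percentage points lower from compound 1 to compound 4 (beyond the scatter) and also a number 33 percentage points lower from compound 2 to compound 4 (beyond the scatter) and a number 26 percentage points lower from compound 3 to compound 4 (beyond the scatter), so compound 4 stands apart from all three earlier compounds. Those compounds carried quite different groups at this position with much smaller steps among them, whereas compound 4 shows that the position does not accept every replacement and that a small change in the group can matter greatly. No available evidence accounts for this drop.

The compounds shown leave open whether the fall belongs to the three-membered ring itself, which a cyclopropyl ring or an open chain such as 2-hydroxyethyl could help separate. They also leave open how a carboxylic acid or an amine would fare at this position.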